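A few compounds are considered here, and "the series" means these few. Any claim that something is new, unique, unknown or untested is made for them only; others in the source may bear on it.

Two compounds have so far been examined in an assay on isolated protein for inhibition of histone acetyltransferase KAT2B (Homo sapiens), read by fluorescence, with a stated time of 15 min; on this read-out higher numbers stand for weaker inhibition and lower numbers for stronger inhibition. Compound 1, `COC(=O)CCn1c(=O)cc(Cl)[s+]1[O-]`, gives 5600 nM in this assay. Compound 2, `CCn1c(=O)c(C)c(Cl)[s+]1[O-]`, carries an ethyl chain on the aromatic nitrogen and a methyl group on the ring. In this assay compound 2 returns > 10000 nM, which is a limit of the measurement and not a number. On the numbers shown, compound 2 therefore stands at the limit of > 10000 nM in this assay, at which 1 of the 2 values shown sits.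

Compound 3, `COC(=O)CCn1c(=O)c(C)c(Cl)[s+]1[O-]`, has not yet been measured. It arises from compound 2 by a single change: methoxycarbonyl in place of hydrogen on a saturated chain carbon, two bonds along the chain from an aromatic nitrogen. For the measured compounds named here, no pair of measured compounds shows this same change on its own, so the size of the step cannot be read from the data. The group that enters is part of the chain that compound 1 carries, and compound 1 gives 5600 nM rather than a limit, so a modest gain in inhibition is expected. The step from compound 2 to compound 3 is estimated as an at least 1.2-fold lower number from compound 2 to compound 3 (0.09 log units; that floor lies within the scatter). Compound 3 is expected to give about 8000 nM, within a range from 3000 nM to 20000 nM, with a real chance that this assay again returns only a limit.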

Compound 3, half-maximal inhibitory concentration: > 10000 nM
Compound 3 gave a limit, no number; the forecaster's own chance of this, stated with the estimate: 40%; middle value at least 1.2-fold (0.09 log units) away from the limit.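

Adding methoxycarbonyl to the chain of compound 2 leaves this assay with only limits at both ends, so the step from compound 2 to compound 3 cannot be read. For the compounds shown here, the one readable comparison now concerns the ring rather than the chain: with the chain held the same, methyl in place of hydrogen on an aromatic carbon gives an at least 1.7-fold higher number from compound 1 to compound 3 (0.25 log units; that floor lies within the scatter). This means that the methoxycarbonyl chain does not by itself secure a measurable number once the ring methyl is present, although the size of the methyl effect cannot be separated from ordinary scatter, and most of the series now rests on a single ceiling: the limit of > 10000 nM in this assay, at which 2 of the 3 values shown sit.

As far as these compounds go, it remains open how far compound 2 and compound 3 actually lie beyond that limit, and so whether the chain helps at all when the ring methyl is present. From the compounds shown here alone, it is also open whether a carboxylic acid or an amine in place of methoxycarbonyl, or a longer chain carrying the same group, would return a real number in this assay.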